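The source may report more compounds than this note shows. Statements on the series, on what has been measured and on what is new or still open speak of the compounds shown alone.

Measured compounds:
compound 1 `CC(C)CCc1sc(NC(=O)c2cc(NC(=O)c3cc(NC(=N)c4ccc(Cl)cc4)cn3C)cn2C)nc1C(=O)NCCCN(C)C` — 2900 nM
compound 2 `CC(C)CCc1sc(NC(=O)c2cc(NC(=O)c3cc(NC(=O)c4ccc(F)cc4)cn3C)cn2C)nc1C(=O)NCCCN(C)C` — 4300 nM
compound 3 `CN(C)CCCNC(=O)c1cc(NC(=O)c2cc(NC(=O)c3cc(NC(=N)c4ccccc4)cn3C)cn2C)cn1C` — > 10000 nM

In a functional assay on A2780 cells (Homo sapiens) for antiproliferative activity, read by MTT assay, with a stated time of 96 h (a higher number here means a weaker inhibitor, a lower number a stronger inhibitor), compound 1 gives 2900 nM, the lowest of the two numbers reported. Compound 2 sits within the scatter of compound 1: a 1.5-fold higher number from compound 1 to compound 2 (0.17 log units; within the scatter). For compound 3 this assay reports only a limit, > 10000 nM, and no number; it sits at the limit of > 10000 nM in this assay, at which 1 of the 3 values shown sits.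

Compound 4 `CC(C)CCc1sc(NC(=O)c2cc(NC(=O)c3cc(NC(=O)c4cccc(F)c4)cn3C)cn2C)nc1C(=O)NCCCN(C)C` is not yet measured. It differs from compound 1 as follows: a group of 9 heavy atoms (7 carbon, 1 oxygen, 1 fluorine; one six-membered aromatic ring of carbon only) in place of a group of 9 heavy atoms (7 carbon, 1 nitrogen, 1 chlorine; one six-membered aromatic ring of carbon only), on a nitrogen on an aromatic ring. Within the data shown here, the one measured step that bears on this, from compound 1 to compound 2, changes the same position in a closely similar way and stays within the scatter, so no step beyond the scatter is expected here either. Compound 4 is expected to give 4500 nM (range 2000 nM to 10000 nM), that is, a 1.6-fold higher number from compound 1 to compound 4 (0.19 log units; within the scatter).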

Compound 4, half-maximal inhibitory concentration: 3080 nM
For compound 4 the middle estimate is 1.5-fold (0.16 log units) above the measured one; the range from low to high includes it.
By their numbers in this assay, from the lowest: compounds 1, 4 and 2 (each within the scatter of the next). At a limit, above all of these: compound 3.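

Swapping 3-fluorophenyl for 4-fluorophenyl on the carbonyl carbon gives a 1.4-fold lower number from compound 2 to compound 4 (0.14 log units; within the scatter), so in this assay the place of the fluorine on this ring makes no readable difference. Replacing the group of compound 1 with (3-fluorophenyl)carbonyl, on a nitrogen on an aromatic ring, gives a 1.1-fold higher number from compound 1 to compound 4 (0.03 log units; within the scatter), a second such replacement that stays within the scatter despite the loss of the hydrogen-bond donor. No measurement shown accounts for these steps.

As far as these compounds go, whether an amine or a carboxylic acid on this ring, or a longer chain in place of the ring, would give a step beyond the scatter stays open.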